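From 4-methylphenyl to 2,6-difluorophenyl on the carbonyl carbon

The source may report more compounds than this note shows. Statements on the series, on what has been measured and on what is new or still open speak of the compounds shown alone.

Compound 1 `Cc1cccc(C(=O)N(C(=S)OCCN2C(=O)c3ccccc3C2=O)c2ccc(Cl)cc2)c1` – 58000 nM
Compound 2 `Cc1ccc(C(=O)N(C(=S)OCCN2C(=O)c3ccccc3C2=O)c2ccc(Cl)cc2)cc1` – > 100000 nM (a limit of the assay)
Compound 3 `Cc1ccc(C(=O)N(C(=S)OCCN2C(=O)c3ccccc3C2=O)c2ccc(C)cc2)cc1` – 83000 nM

These values come from an ADME assay on MT4 cells (Homo sapiens) for cytotoxicity, read by MTT assay (on this read-out higher numbers stand for lower toxicity in this test and lower numbers for higher toxicity in this test), and form a narrow set. Compound 3 gives 83000 nM and lies within the scatter of compound 1, its nearest number. Compound 4 `Cc1ccc(N(C(=O)c2c(F)cccc2F)C(=S)OCCN2C(=O)c3ccccc3C2=O)cc1` carries 2,6-difluorophenyl in place of 4-methylphenyl on a carbonyl carbon. At that same place, the measured change shows an at least 1.7-fold higher number from compound 1 to compound 2 (0.23 log units; that floor lies within the scatter). Methyl in place of chloro on an aromatic carbon shows an at least 1.2-fold lower number from compound 2 to compound 3 (0.08 log units; that floor lies within the scatter). Neither step involves fluorine, and neither gives reason to expect a shift beyond the scatter. The expected result is a 1.2-fold lower number from compound 3 to compound 4 (0.07 log units; within the scatter). Compound 4 is estimated at 70000 nM, with an expected range from 30000 nM to 100000 nM.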

Compound 4, half-maximal cytotoxic concentration: 65000 nM
Compound 4: the middle estimate sits 1.1-fold (0.03 log units) above what was measured; the measured number falls inside the stated range.
By their numbers in this assay, from the lowest: compounds 1, 4 and 3 (each within the scatter of the next). At a limit, above all of these: compound 2.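

Replacing 4-methylphenyl with 2,6-difluorophenyl on the carbonyl carbon in this assay gives a 1.3-fold lower number from compound 3 to compound 4 (0.11 log units; within the scatter). This place, so far probed only with methylphenyl groups, therefore also accepts a fluorine-bearing group without a step beyond the scatter. Compound 2 remains a limit and not a number: the limit of > 100000 nM in this assay, at which 1 of the 4 values shown sits.

From the compounds shown here alone, whether an aminophenyl or a carboxyphenyl group on this carbonyl carbon would give a step beyond the scatter stays open. Also open, going by these compounds, is how 2,6-difluorophenyl reads together with chloro in place of methyl on the aromatic carbon.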